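Alpha-Methyl Substitution on a Carboxymethyl Side Chain

The source may report more compounds than this note shows. Statements on the series, on what has been measured and on what is new or still open speak of the compounds shown alone.

Three compounds built on a shared core were tested in a functional assay on HFL1 cells for antagonist activity at sphingosine 1-phosphate receptor 2 (Homo sapiens), read by ELISA, with a stated time of 24 h, in the presence of a further agent that is not named here; a higher number here means a weaker inhibitor, a lower number a stronger inhibitor. Compound 1 `CC(C(=O)O)c1nn(Cc2cn3cc(OCC4CC4)c(Cl)cc3n2)c2ccccc2c1=O` gives 15 nM in this assay. Compound 3 `O=C(O)Cc1nn(Cc2cn3cc(OCC4CC4)c(Cl)cc3n2)c2ccccc2c1=O` gives 60 nM in this assay. Compound 2 `O=C(O)Cn1nc(Cn2cc3cc(OCC4CC4)c(Cl)cc3n2)c2ccccc2c1=O` gives 647 nM in this assay, the highest number of the three; its nearest neighbour is compound 3 and the furthest is compound 1. The difference between the cores of compound 2 and compound 3 is not broken down here, since the two have the same atoms joined differently.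

Within the core of compound 3, the change methyl in place of hydrogen on a saturated chain carbon bound to an aromatic carbon and a carbonyl carbon produced a 4.0-fold lower number from compound 3 to compound 1 (0.60 log units; beyond the scatter).

Compound 4 `C[C@H](C(=O)O)n1nc(Cn2cc3cc(OCC4CC4)c(Cl)cc3n2)c2ccccc2c1=O` has not been measured in this assay. It differs from compound 2 by methyl in place of hydrogen on a saturated chain carbon bound to an aromatic nitrogen and a carbonyl carbon. This is the same kind of change as that from compound 3 to compound 1, but not the same: in the measured pair the methyl sits on a saturated chain carbon bound to an aromatic carbon and a carbonyl carbon, while in the new pair it sits on a saturated chain carbon bound to an aromatic nitrogen and a carbonyl carbon.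

Going by the values given here, the expected step is a 2.9-fold lower number from compound 2 to compound 4 (0.47 log units; beyond the scatter), somewhat smaller than the measured one, because the only precedent is a 4.0-fold lower number from compound 3 to compound 1 (0.60 log units; beyond the scatter) on a different core and the transfer across cores is uncertain. Compound 4 is therefore expected to give about 220 nM in this assay, with a likely range from 90 nM to 550 nM.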

Compound 4, half-maximal inhibitory concentration: 197 nM
The estimate for compound 4 lay 1.1-fold (0.05 log units) above the measured number, and the stated range covers the measured number.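

Replacing carboxymethyl with 1-carboxyethyl on the core of compound 2 gave a 3.3-fold lower number from compound 2 to compound 4 (0.52 log units; beyond the scatter) in this assay. Set beside the earlier step, the change carried over between these two cores in direction and in size, although the methyl sits on a saturated chain carbon bound to an aromatic nitrogen in one pair and on one bound to an aromatic carbon in the other: the same change on two cores in this assay, a 4.0-fold lower number (0.60 log units; beyond the scatter) from compound 3 to compound 1 and a 3.3-fold lower number (0.52 log units; beyond the scatter) from compound 2 to compound 4, 1.2-fold (0.09 log units) apart, within the scatter of two such steps This agreement rests on just two pairs, so it supports transfer between these two cores only and shows neither that the change would hold on any other core nor why it lowers the number.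

The compounds shown leave open whether an ethyl group in place of the added methyl, or a second methyl on the same carbon, would lower the number further, and how the mirror-image form of the 1-carboxyethyl group of compound 4 would compare. They also leave open what would happen on either core if an amide or a tetrazole took the place of the carboxylic acid.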